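A few compounds are considered here, and "the series" means these few. Any claim that something is new, unique, unknown or untested is made for them only; others in the source may bear on it.

In a functional assay on A-375 cells (Homo sapiens) for cytotoxicity, read by MTT assay, with a stated time of 72 h (a higher number here means a weaker inhibitor, a lower number a stronger inhibitor), compound 1 (`O=C1c2c[n+]([O-])c3ccccc3c2C(=O)c2c1c1ccccc1n2Cc1cn([C@@H]2C[C@H](O)[C@@H](CO)O2)nn1`) gives 20 nM as its reading, compound 2 (`CC1(C)OCC(Cn2cc(Cn3c4c(c5ccccc53)C(=O)c3c[n+]([O-])c5ccccc5c3C4=O)nn2)O1`) gives 330 nM and compound 3 (`O=C1c2c[n+]([O-])c3ccccc3c2C(=O)c2c1c1ccccc1n2Cc1cn(CC(O)CO)nn1`) gives 440 nM on the same test. Compound 3 has the highest number of the three, but it sits level with its nearest neighbour (a 1.3-fold higher number from compound 2 to compound 3 (0.12 log units; within the scatter)). Compound 1, the strongest, stands well apart from the other two (a 17-fold higher number from compound 1 to compound 2 (1.22 log units; beyond the scatter)) and (a 22-fold higher number from compound 1 to compound 3 (1.34 log units; beyond the scatter)).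

Compound 4 (`CC1(C)OC[C@H](Cn2cc(Cn3c4c(c5ccccc53)C(=O)c3c[n+]([O-])c5ccccc5c3C4=O)nn2)O1`) differs from compound 3 in a single place (2,2-dimethyl-1,3-dioxolan-4-yl in place of 1,2-dihydroxyethyl on a saturated chain carbon bound to an aromatic nitrogen). A 2,2-dimethyl-1,3-dioxolan-4-yl group enters in place of 1,2-dihydroxyethyl, on a saturated chain carbon bound to an aromatic nitrogen. Compound 2 carries this same group, drawn without a defined stereocentre, so the step between compound 2 and compound 3 is the one that bears most directly. That step stayed within the scatter. The two large steps start from the 4-hydroxy-5-(hydroxymethyl)oxolan-2-yl group of compound 1 and say little here. Among the compounds with values here, no compound yet shows what the defined stereocentre of compound 4 does, so the range must stay wide. No step beyond the scatter is therefore expected in this assay. The expected change is small (a 1.3-fold lower number from compound 3 to compound 4 (0.12 log units; within the scatter)). Compound 4 is estimated at 330 nM (expected range 130 nM to 800 nM) in this test.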

Compound 4, half-maximal inhibitory concentration: 180 nM
Compound 4: middle estimate off by 1.8-fold (0.26 log units), on the high side; the measured number falls inside the stated range.
By their numbers in this assay, from the lowest: compound 1; then compounds 4, 2 and 3 (each within the scatter of the next, the first and the last beyond it).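

In this assay, exchanging 1,2-dihydroxyethyl for 2,2-dimethyl-1,3-dioxolan-4-yl on the saturated chain carbon bound to an aromatic nitrogen now gives a change beyond the scatter, a 2.4-fold lower number from compound 3 to compound 4 (0.39 log units; beyond the scatter), whereas the same exchange with the stereocentre left undefined, in compound 2, had stayed within it. Even so, compound 1 remains the strongest of the four, and this group does not close the distance to its 4-hydroxy-5-(hydroxymethyl)oxolan-2-yl group, with a 9.0-fold higher number from compound 1 to compound 4 (0.95 log units; beyond the scatter). The S configuration drawn in compound 4 cannot be credited with a real effect, since a 1.8-fold lower number from compound 2 to compound 4 (0.26 log units; within the scatter) lies within the scatter and the comparison rests only on this: the fact that one of compounds 2 and 4 is drawn with a defined configuration and the other without, at the place where they differ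

The compounds shown leave open how the form drawn R at this ring carbon would read, and so whether configuration here matters at all. They also do not separate the ring from the other parts of the exchange: an open 2,3-dimethoxypropyl chain, an amine or a carboxylic acid at this place would each test a different part of it.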